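Putting a carbon ring back on the sulfonyl sulfur

The source may report more compounds than this note shows. Statements on the series, on what has been measured and on what is new or still open speak of the compounds shown alone.

Of the compounds shown here, three have been tested in a functional assay on DLD-1 cells (Homo sapiens) for antiproliferative activity, read by CellTiter-Glo, with a stated time of 72 h; on this read-out higher numbers stand for weaker inhibition and lower numbers for stronger inhibition. Compound 1 `Cc1ccc(S(=O)(=O)N2CCC(N3CCC(C)CC3)CC2)cc1C` gives 24 nM and compound 3 `Cc1cc(C)c(S(=O)(=O)N2CCC(N3CCC(Cc4ccccc4F)CC3)CC2)c(C)c1` gives 74 nM. Compound 2 `CC1CCN(C2CCN(S(=O)(=O)c3nccn3C)CC2)CC1` stands at the limit of > 5000 nM in this assay, at which 1 of the 3 values shown sits; its value > 5000 nM is a limit of the assay rather than a number, and it marks the weak end of what has been measured so far. Going by the values given here, only one pair differs in a single place, and that step, an at least 200-fold higher number from compound 1 to compound 2 (2.31 log units; beyond the scatter), shows how much is lost when 1-methyl-1H-imidazol-2-yl takes the place of 3,4-dimethylphenyl on the sulfonyl sulfur. Compound 4 `CC1CCN(C2CCN(S(=O)(=O)c3cc(Cl)cc(Cl)c3)CC2)CC1` has not yet been measured. It differs from compound 2 in one place: 3,5-dichlorophenyl in place of 1-methyl-1H-imidazol-2-yl on a sulfonyl sulfur. This change runs the measured step backward in kind, returning a six-membered aromatic ring of carbon only to the sulfonyl sulfur, so a large fall in the number is expected, roughly undoing the loss seen in an at least 200-fold higher number from compound 1 to compound 2 (2.31 log units; beyond the scatter). Compound 4 is therefore expected to give about 40 nM, most likely between 10 nM and 200 nM, which would mean an estimated step of an at least 120-fold lower number from compound 2 to compound 4 (2.09 log units; beyond the scatter).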

Compound 4, half-maximal inhibitory concentration: 3400 nM
Compound 4: middle estimate off by 85-fold (1.93 log units), on the low side, and the stated range ends below it.
By their numbers in this assay, from the lowest: compound 1; then compound 3; then compound 4. At a limit, above all of these: compound 2.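

Having a six-membered aromatic ring of carbon only on the sulfonyl sulfur is not enough by itself: in this assay, 3,5-dichlorophenyl in place of 3,4-dimethylphenyl gives a 140-fold higher number from compound 1 to compound 4 (2.15 log units; beyond the scatter). So at this position, the groups carried by the ring matter, not just the kind of ring. Against 1-methyl-1H-imidazol-2-yl, all that can be read is a floor, an at least 1.4-fold lower number from compound 2 to compound 4 (0.16 log units; that floor lies within the scatter), and compound 2 has no exact number, only a limit: the limit of > 5000 nM in this assay, at which 1 of the 4 values shown sits.

The compounds shown do not separate the effect of swapping methyl for chlorine from the effect of where these groups sit on the ring. A 3,4-dichlorophenyl or 3,5-dimethylphenyl group on the sulfonyl sulfur would address that question, and a pyridine ring there would test a six-membered aromatic ring containing nitrogen.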